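A Fluoro Step Measured Once and Expected Again

The compounds below may be only part of what the source reports. "The series", "measured", "known", "first", "only" and "open" are said of these compounds alone.

Measured compounds:
compound 1, `C(=N/c1ccccc1)\c1cc(-c2ccccc2)no1`, > 100000 nM
compound 2, `Fc1ccc(-c2cc(/C=N/c3ccccc3)on2)cc1`, 36500 nM
compound 3, `CCc1cc2ccccc2nc1-c1cc(-c2ccccc2)no1`, > 100000 nM

In a functional assay on PC-3 cells (Homo sapiens) for inhibition, read by MTT assay, with a stated time of 24 h (on this read-out higher numbers stand for weaker inhibition and lower numbers for stronger inhibition), compound 1 reaches only a limit of the assay, > 100000 nM. Compound 2 gives a number in this assay, 36500 nM. Compound 3 again stands at a limit, > 100000 nM, so nothing beyond that is known of it. The change from compound 1 to compound 2, (fluoro in place of hydrogen on an aromatic carbon), made a step of an at least 2.7-fold lower number from compound 1 to compound 2 (0.43 log units; beyond the scatter). Compound 4, `CCc1cc2ccccc2nc1-c1cc(-c2ccc(F)cc2)no1`, is not yet measured; it differs from compound 3 by fluoro in place of hydrogen on an aromatic carbon, the same change at a place described in the same words. How the core of compound 3 differs from that of compound 1 is not broken down here. Compound 4 is expected to show a step of an at least 1.6-fold lower number from compound 3 to compound 4 (0.22 log units; that floor lies within the scatter), in line with the earlier step and, because of the limit of > 100000 nM in this assay, at which 2 of the 3 values shown sit, with a fair chance that only a limit is reported again. Compound 4 is therefore estimated at 60000 nM, between 25000 nM and 150000 nM.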

Compound 4, half-maximal inhibitory concentration: > 100000 nM
Compound 4: only a limit was reported; the forecaster's own chance of this, stated with the estimate: 45%; at least 1.6-fold (0.22 log units) between middle value and limit.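

In this assay compound 4 gives > 100000 nM, a limit of the assay and not a number. For the compounds shown here, compound 3 stands at such a limit too, so no step between compound 3 and compound 4 can be read: the limit of > 100000 nM in this assay, at which 3 of the 4 values shown sit. The compounds shown leave open whether fluoro in place of hydrogen changes the number at all on the core of compound 3.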